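Notes on compound 1 and the proposed compound 4

The compounds below may be only part of what the source reports. "The series", "measured", "known", "first", "only" and "open" are said of these compounds alone.

Measured so far:
compound 1, `CN(O)/C=C\C(=O)c1ccc([N+](=O)[O-])cc1`, 1500 nM; compound 2, `COc1ccc(C(=O)/C=C\N(C)O)cc1`, 6000 nM; compound 3, `CN(O)/C=C\C(=O)c1ccc(Cl)cc1`, 550 nM.

In an assay on RBL-1 cells for inhibition of Polyunsaturated fatty acid 5-lipoxygenase (Rattus norvegicus) (a higher number here means a weaker inhibitor, a lower number a stronger inhibitor), compound 1 sits second highest of the three, with compound 3 nearest at a 2.7-fold lower number from compound 1 to compound 3 (0.44 log units; beyond the scatter), and compound 2 furthest at a 4.0-fold higher number from compound 1 to compound 2 (0.60 log units; beyond the scatter). Between the two neighbours the gap is an 11-fold lower number from compound 2 to compound 3 (1.04 log units; beyond the scatter). All three measured steps exchange the group on the aromatic carbon of the shared core; none touches the other end of the molecule.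

Compound 4, `O=C(/C=C\N(O)Cc1ccccc1)c1ccc([N+](=O)[O-])cc1`, is compound 1 with phenyl in place of hydrogen on a saturated chain carbon bound to an amine nitrogen, the same difference cut one bond further out reading methyl to benzyl. Within the data shown here, no measured step bears on this position, so there is no anchor for the size or direction of the change in this assay beyond the observation that the measured compounds span a moderate range. The expected step from compound 1 to compound 4 is therefore no change at the digits printed from compound 1 to compound 4 (within the scatter), essentially none beyond the scatter, with wide uncertainty. Compound 4 is estimated at 1500 nM, range 400 nM to 6000 nM.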

Compound 4, half-maximal inhibitory concentration: 2500 nM
The estimate for compound 4 lay 1.7-fold (0.22 log units) below the measured number, and the stated range covers the measured number.
By their numbers in this assay, from the lowest: compound 3; then compounds 1 and 4 (each within the scatter of the next); then compound 2.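

In this assay, among these compounds, the first measured change at this end of the molecule, phenyl in place of hydrogen on a saturated chain carbon bound to an amine nitrogen, gives a 1.7-fold higher number from compound 1 to compound 4 (0.22 log units; within the scatter). With nitro held on the aromatic carbon, this position therefore takes the step from methyl to benzyl without a difference beyond the scatter, whereas all three earlier steps, made on the aromatic carbon, lay beyond it. No supporting measurement accompanies this result, so nothing here accounts for it.

A single pair leaves open how other groups behave at this place, such as a carboxylic acid in place of the phenyl or a longer chain ending in phenyl. It also leaves open whether methyl to benzyl gives a similar step with chloro or methoxy on the aromatic carbon.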